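The source may report more compounds than this note shows. Statements on the series, on what has been measured and on what is new or still open speak of the compounds shown alone.

Compound 3 `CCOC(=O)CCCCCOc1cccc(CN(C(=O)c2ccc(-c3cccc(OC(C)C)c3)cc2)C(C)C)c1` was tested in an ADME assay on HepG2 cells (Homo sapiens) for cytotoxicity, read by CellTiter-Glo and resazurin assay, with a stated time of 72 h; a lower number here means that less compound is needed, a higher number that more compound is needed for the effect. In this assay compound 3 gives > 26000 nM, which is a limit of the assay rather than a number. Compound 1 `CC(C)N(Cc1cccc(OCCCCCC(=O)O)c1)C(=O)c1ccc(-c2cccc(N(C)C)c2)cc1` also reaches a limit in this assay, reading > 26000 nM. Compound 2 `CC(C)Oc1cccc(-c2ccc(C(=O)N(Cc3cccc(OCCCCCC(=O)O)c3)C(C)C)cc2)c1` likewise shows only a limit, > 26000 nM. All three values share (the limit of > 26000 nM in this assay, at which 3 of the 3 values shown sit). The step that the two limits leave unreadable from compound 1 to compound 2 and the step that the two limits leave unreadable from compound 2 to compound 3 are both unreadable, as each joins two limits. Compound 4 `CCOC(=O)CCCCCOc1cccc(CN(C(=O)c2ccc(-c3cccc(Br)c3)cc2)C(C)C)c1` differs from compound 3 by bromo in place of isopropoxy on an aromatic carbon. Going by the values given here, no measured step speaks to this change, and with every value so far resting at the limit, no shift beyond the scatter is expected. The step that the limit leaves unreadable from compound 3 to compound 4 is the expected change. Compound 4 is estimated to give 30000 nM, between 15000 nM and 60000 nM.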

Compound 4, half-maximal effective concentration: > 26000 nM
Compound 4 gave a limit, no number (the forecaster's own chance of this, stated with the estimate: 80%); the middle value does not contradict the limit.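

Going by these compounds alone, compound 3 and compound 4 both rest at a limit rather than a number, so no step between them can be read: the limit of > 26000 nM in this assay, at which 4 of the 4 values shown sit. From the compounds shown here alone, what concentration any of these four compounds would need for the effect in this assay stays open.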